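The source may hold more compounds than are shown below. What is called first, only, known or untested is meant among the compounds shown, and "the series" means these compounds.

Series notes. The shared core carries a 4-methoxyphenyl in compound 2 `C=CC[C@H]1C[C@]2([C@@H](C)Cc3ccc(OC)cc3)OCOC2=CC1=O`, which in a functional assay on M14 cells (Homo sapiens) for antiproliferative activity, with a stated time of 72 h (on this read-out lower numbers stand for stronger inhibition and higher numbers for weaker inhibition), gives 20 nM, the lowest of the three numbers in hand. Compound 1 `C=CC[C@H]1C[C@]2([C@@H](C)Cc3ccc(OC)c(OC)c3)OCOC2=CC1=O`, bearing a further methoxy on that ring, gives 110 nM in this assay; compound 3 `C=CC[C@H]1C[C@]2([C@@H](C)Cc3cccc(OC)c3)OCOC2=CC1=O`, with the single methoxy moved, gives 8800 nM. The steps run a 5.5-fold lower number from compound 1 to compound 2 (0.74 log units; beyond the scatter), an 80-fold higher number from compound 1 to compound 3 (1.90 log units; beyond the scatter) and a 440-fold higher number from compound 2 to compound 3 (2.64 log units; beyond the scatter), so both steps to compound 3 are large while the step from compound 1 to compound 2 is modest.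

Compound 4 `C=CC[C@H]1C[C@]2([C@@H](C)Cc3ccc(OC)c(C)c3)OCOC2=CC1=O` is not yet measured. Relative to compound 2 the change is methyl in place of hydrogen on an aromatic carbon. Going by the values given here, the only measured step that touches this aromatic carbon is a 5.5-fold lower number from compound 1 to compound 2 (0.74 log units; beyond the scatter), which read in reverse shows that a methoxy on that carbon costs a modest amount; no methyl has been tried anywhere on this ring, and the large steps to compound 3 concern a different carbon. A methyl there is expected to cost no more than the methoxy did, so in this assay the step of a 2.0-fold higher number from compound 2 to compound 4 (0.30 log units; within the scatter) is expected, a small rise within or just beyond the scatter. Compound 4 is therefore estimated at 40 nM, within 12 nM to 150 nM.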

Compound 4, half-maximal inhibitory concentration: 410 nM
Beside the measured number, compound 4's estimate is 10-fold (1.01 log units) below it; measured number outside the range, above it.
By their numbers in this assay, from the lowest: compound 2; then compound 1; then compound 4; then compound 3.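

In this assay, methyl in place of hydrogen on the aromatic carbon ortho to a methoxy group gives a 21-fold higher number from compound 2 to compound 4 (1.31 log units; beyond the scatter), a large step, so this carbon is more sensitive to substitution than the step from compound 1 to compound 2 alone showed. Methyl in place of methoxy on the same carbon gives a 3.7-fold higher number from compound 1 to compound 4 (0.57 log units; beyond the scatter), a modest step, so across these three compounds the order on this carbon, from the lowest number, runs hydrogen, methoxy, methyl, and the number does not simply rise with the heavy atoms of the group placed there. Nothing in hand accounts for this order.

The compounds shown leave open where a fluorine, a chlorine or a hydroxyl on this carbon would fall relative to compound 2 and compound 4, and whether an ethyl would extend the rise seen with methyl. They also leave open whether a methyl here costs as much without the neighbouring methoxy group, as compound 1 and compound 4 both retain that group.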